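The compounds below may be only part of what the source reports. "The series", "measured", "known", "first", "only" and "open" are said of these compounds alone.

Measured compounds:
- compound 1, `COc1ccccc1-n1nc(C2CC(C)(C)OC(C)(C)C2)cc1-c1ccc(C)nc1`: 13000 nM in an assay on HEK293 cells for inhibition of Voltage-dependent N-type calcium channel subunit alpha-1B (Homo sapiens), read by patch clamp, using a membrane potential dye; a higher number here means a weaker inhibitor, a lower number a stronger inhibitor
- compound 2, `COc1ccccc1-n1nc(C2CCOC(C)(C)C2)cc1-c1ccc(Cl)cc1`: 55 nM

Going by the values given here, compound 1 holds the higher of the two numbers in this assay; compound 2 sits far lower, and the two structures differ in more than one place, so their values show only that the pair lies well apart and nothing about any single change.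

Compound 3, `COc1ccccc1-n1nc(C2CC(C)(C)OC(C)(C)C2)cc1-c1ccnc(Cl)c1`, has not yet been measured. It differs from compound 1 as follows: 2-chloropyridin-4-yl in place of 6-methylpyridin-3-yl on an aromatic carbon

Among the compounds with values here, no measured pair isolates this change. Compound 2 carries a chlorine-bearing aryl ring on the same ring position and gives the lower number, yet its oxane ring also differs from that of compound 1, so the comparison is indirect. On that basis a moderate drop in the number from compound 1 to compound 3 is expected, with wide uncertainty.

Compound 3 is estimated at 4000 nM in this assay, with a likely range of 800 nM to 20000 nM. This estimate corresponds to an expected step of a 3.3-fold lower number from compound 1 to compound 3 (0.51 log units; beyond the scatter).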

Compound 3, half-maximal inhibitory concentration: 250 nM
Compound 3: middle estimate off by 16-fold (1.20 log units), on the high side; measured number below the stated range.
By their numbers in this assay, from the lowest: compound 2; then compound 3; then compound 1.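

Going by these compounds alone, with the 2,2,6,6-tetramethyloxan-4-yl group and the 2-methoxyphenyl group held fixed, compound 3 gives the first direct reading of this aromatic carbon: in this assay, 2-chloropyridin-4-yl in place of 6-methylpyridin-3-yl brings a 52-fold lower number from compound 1 to compound 3 (1.72 log units; beyond the scatter) and so counts as a large step. The position is therefore sensitive to the identity of the aryl ring, and the tetramethyloxane ring does not by itself hold a compound at a number as high as that of compound 1. Within this single pair, the exchange alters both the substituent on the pyridine, chlorine against methyl, and the point at which the pyridine is attached, and nothing shown accounts for the size of the step.

As far as these compounds go, it remains open which of those two alterations carries the step, a question that 6-chloropyridin-3-yl or 2-methylpyridin-4-yl at this position would separate. Also open, from the compounds shown here alone, are whether a methoxy group or an amine could take the place of the chlorine on the pyridine, and whether the same exchange would give a step of similar size on the less substituted oxane ring of compound 2.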